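This account rests on a few compounds, and the source may have more. Where it says the series, first, only, none or still open, it means among the compounds named here.

Of the compounds shown here, three from one series have been measured in an in vitro assay on HEK385-7 cells for displacement of a labelled ligand from prostaglandin D2 receptor 2 (Homo sapiens); on this read-out lower numbers stand for stronger inhibition and higher numbers for weaker inhibition. Compound 1 `O=C(O)Cc1sc(NCc2ccccc2)nc1-c1ccc(Cl)cc1` gives 440 nM, compound 2 `O=C(O)Cc1sc(COc2ccc(Cl)cc2)nc1-c1ccc(Cl)cc1` gives 32 nM, and compound 3 `NS(=O)(=O)c1ccc(-c2nc(C(c3ccc(F)cc3)c3ccc(F)cc3)sc2CC(=O)O)cc1` gives 1500 nM. Compound 3 therefore stands at the highest number of the three, the weakest inhibition seen so far: the nearest value is that of compound 1, which lies beyond the usual scatter, and the furthest is that of compound 2.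

Compound 4 `O=C(O)Cc1sc(C(c2ccc(F)cc2)c2ccc(F)cc2)nc1-c1ccnc(Cl)c1` has not yet been measured. It keeps the shared core and the carboxymethyl group of compound 3, and the change is 2-chloropyridin-4-yl in place of 4-sulfamoylphenyl on an aromatic carbon. Within the data shown here, no measured pair shows this exact step, so its size has to be judged from the values at hand. Compound 1, which carries a chlorine on an aromatic ring at this side of the core, gives the lower number 440 nM, and compound 2, which also carries a chlorine on an aromatic ring at this side of the core, gives the lower number 32 nM. A move toward stronger inhibition is therefore expected for compound 4. The expected step is a 7.5-fold lower number from compound 3 to compound 4 (0.88 log units; beyond the scatter), and compound 4 is estimated at 200 nM, within a range from 40 nM to 900 nM.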

Compound 4, half-maximal inhibitory concentration: 3.1 nM
Estimate against measurement, compound 4: 65-fold (1.81 log units) above, outside the stated range (below it).
By their numbers in this assay, from the lowest: compound 4; then compound 2; then compound 1; then compound 3.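

Replacing 4-sulfamoylphenyl with 2-chloropyridin-4-yl on the aromatic carbon next to the ring nitrogen gives a 480-fold lower number from compound 3 to compound 4 (2.68 log units; beyond the scatter) in this assay and is the first change shown in one place alone. With the rest of the molecule held fixed, the group at this position can by itself move the number by a very large step, so the position is far from indifferent to what it carries. Nothing measured here accounts for the size of this step.

The step changes several things at once, so it leaves open whether the ring nitrogen, the chlorine or the departure of the sulfamoyl group matters most. A plain phenyl or an unsubstituted pyridin-4-yl at this position on the same core would help tell these apart.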